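Replacing a fluorinated phenyl with a carboxyphenyl on compound 2

The compounds below may be only part of what the source reports. "The series", "measured", "known", "first", "only" and "open" are said of these compounds alone.

Measured in an ADME assay on CHO cells (Cricetulus griseus) for cytotoxicity, read by MTT assay; on this read-out lower numbers stand for higher toxicity in this test and higher numbers for lower toxicity in this test:
- compound 1 `CN1CCN(CC2CCN(c3nccc4[nH]c(-c5ccc(F)c(C(F)(F)F)c5)nc34)CC2)CC1`: 3100 nM
- compound 2 `CN1CCN(CC2CCN(c3nccc4[nH]c(-c5cc(F)cc(C(F)(F)F)c5)nc34)CC2)CC1`: 3100 nM

Among the compounds with values here, compound 2 stands level with compound 1, its only measured neighbour. Within the data shown here, the one measured step shows no change at the digits printed from compound 1 to compound 2 (within the scatter), and it only rearranges the same groups on the phenyl ring.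

Compound 3 `CN1CCN(CC2CCN(c3nccc4[nH]c(-c5cccc(C(=O)O)c5)nc34)CC2)CC1` changes far more: it carries 3-carboxyphenyl in place of 3-fluoro-5-(trifluoromethyl)phenyl on an aromatic carbon. Among the measured compounds shown here, no measured compound carries this group, so the data offer no direct guide to the size of the effect in this assay. The expectation therefore starts from compound 2 at 3100 nM and is a judgement, with a wide range. The expected step is a 3.9-fold higher number from compound 2 to compound 3 (0.59 log units; beyond the scatter), an estimate leaning towards higher numbers, meaning lower toxicity in this test. For compound 3 the estimated value is 12000 nM, with an expected range from 3500 nM to 45000 nM.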

Compound 3, half-maximal cytotoxic concentration: > 50000 nM
Compound 3 gave a limit, no number; the forecaster's own chance of this, stated with the estimate: 30%; at least 4.1-fold (0.61 log units) between middle value and limit.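

In this assay compound 3 gives > 50000 nM, a limit of the assay and not a number. The earlier pair showed only that rearranging the fluorine and trifluoromethyl on the phenyl ring left the read-out level, whereas the change to 3-carboxyphenyl gives an at least 16-fold higher number from compound 2 to compound 3 (1.20 log units; beyond the scatter) and an at least 16-fold higher number from compound 1 to compound 3 (1.20 log units; beyond the scatter), towards lower toxicity in this test, so what this phenyl ring carries does matter here. The full size of these steps cannot be read: the limit of > 50000 nM in this assay, at which 1 of the 3 values shown sits.

The carboxylic acid arrives in the same change that removes the fluorine and the trifluoromethyl, so the effect of adding one cannot be separated from the effect of losing the others. Nor do these compounds show whether a plain phenyl, a methyl ester or a primary amide in this place would behave like the carboxylic acid.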